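The source may report more compounds than this note shows. Statements on the series, on what has been measured and on what is new or still open speak of the compounds shown alone.

Measured so far:
compound 1 `COc1ccc(/C=C/C(=O)NCCCC(C)Nc2cc(OC)cc3cccnc23)cc1`, > 240000 nM
compound 2 `COc1cc(NC(C)CCCNC(=O)/C=C/c2ccc(Cl)cc2)c2ncccc2c1`, 16800 nM
compound 3 `COc1cc(NC(C)CCCNC(=O)NCCCO)c2ncccc2c1`, "not determined" (no result reported)

In an ADME assay on L6 cells (Rattus norvegicus) for cytotoxicity, read by resazurin assay, with a stated time of 70 h (a higher number here means a weaker inhibitor, a lower number a stronger inhibitor), compound 1 gives > 240000 nM, which is a limit of the assay and not a number. Compound 2 gives 16800 nM. Going by the values given here, the only measured step is an at least 14-fold lower number from compound 1 to compound 2 (1.15 log units; beyond the scatter). Compound 3 stands with no number in this assay, its result being "not determined" (no result reported). The compound to be measured is compound 4 `COc1cc(NC(C)CCCNC(=O)NNC(=O)/C=C/c2ccccc2)c2ncccc2c1`, which differs from compound 3 by ((2-phenylethenyl)carbonyl)amino in place of 3-hydroxypropyl on an amide-type nitrogen. Among the compounds with values here, the single measured step, between compound 1 and compound 2, changes an aromatic substituent and bears only loosely on a change at the amide nitrogen. Among the values shown, one sits at the limit of > 240000 nM in this assay, at which 1 of the 3 values shown sits, so the series reaches from a limit down to a measured number. For compound 4 the expected value in this assay is 60000 nM, with a range of 15000 nM to 240000 nM.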

Compound 4, half-maximal inhibitory concentration: 13900 nM
Estimate against measurement, compound 4: 4.3-fold (0.64 log units) above; measured number below the stated range.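

No new step can be read: compound 3 gives "not determined" (no result reported), so compound 4, at 13900 nM, has no partner value for comparison. The compounds shown leave open what ((2-phenylethenyl)carbonyl)amino in place of 3-hydroxypropyl does to this number.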